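A few compounds are considered here, and "the series" means these few. Any claim that something is new, unique, unknown or untested is made for them only; others in the source may bear on it.

Measured so far in a functional assay on HepG2 cells (Homo sapiens) for antiproliferative activity, read by MTT assay, with a stated time of 24 h; on this read-out lower numbers stand for stronger inhibition and higher numbers for weaker inhibition: compound 1 `C#CCOc1ccc2c(=O)c(-c3cc(OC)c(OC)cc3OC)coc2c1` gives 4950 nM; compound 2 `COc1ccc2c(=O)c(-c3cc(OC)c(OC)cc3OC)coc2c1` gives 2040 nM.

Compound 2 stands lowest of the two numbers, with compound 1 next at a 2.4-fold lower number from compound 1 to compound 2 (0.38 log units; beyond the scatter) reversed. Compound 3 `COc1cc(OC)c(-c2coc3cc(OCc4ccc(Br)cc4)ccc3c2=O)cc1OC` differs from compound 2 by 4-bromophenyl in place of hydrogen on a saturated chain carbon bound to an oxygen on an aromatic ring. Among the measured compounds shown here, the only step that bears on it is a 2.4-fold lower number from compound 1 to compound 2 (0.38 log units; beyond the scatter), where removing a substituent at that same carbon lowered the number modestly; compound 3 adds a substituent there instead, so a modest rise in this assay is expected, a 2.2-fold higher number from compound 2 to compound 3 (0.34 log units; beyond the scatter). Compound 3 is estimated at 4500 nM, range 1500 nM to 13000 nM.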

Compound 3, half-maximal inhibitory concentration: 1050 nM
The estimate for compound 3 lay 4.3-fold (0.63 log units) above the measured number; measured number below the stated range.
By their numbers in this assay, from the lowest: compounds 3 and 2 (each within the scatter of the next); then compound 1.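

In this assay, placing 4-bromophenyl on the saturated chain carbon bound to an oxygen on an aromatic ring leaves the read-out within the scatter (a 1.9-fold lower number from compound 2 to compound 3 (0.29 log units; within the scatter)), so methoxy and (4-bromobenzyl)oxy cannot be told apart here. Substitution at this carbon therefore does not in itself carry a penalty, as compound 1 alone might have suggested, and the group matters (a 4.7-fold lower number from compound 1 to compound 3 (0.67 log units; beyond the scatter)). Nothing measured bears on the cause. Open, as far as these compounds go, is how an amine or a carboxylic acid at this carbon would read. Also open, from the compounds shown here alone, is whether the bromine contributes, which an unsubstituted benzyl would test.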